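A few compounds are considered here, and "the series" means these few. Any claim that something is new, unique, unknown or untested is made for them only; others in the source may bear on it.

Compound 1 `O=C(CCCCCCc1ccccc1)c1ncc(-c2cccc(C(=O)C(F)(F)F)c2)o1` is the stronger of the two measured compounds: in an assay (Rattus norvegicus) for inhibition of Fatty-acid amide hydrolase 1 (Homo sapiens) (a lower number here means a stronger inhibitor, a higher number a weaker inhibitor), compound 1 gives 16 nM. Compound 2 `Nc1ccc(-c2cnc(C(=O)CCCCCCc3ccccc3)o2)cc1` gives in this assay a value of 90 nM, the higher of the two numbers. Among the measured compounds shown here, its only neighbour is compound 1, whose number is lower, and the gap between the two lies beyond the scatter of repeated measurements.

Compound 3 `O=C(CCCCCCc1ccccc1)c1ncc(C(=O)C(F)(F)F)o1` is not yet measured. It differs from compound 2 in one place ((trifluoromethyl)carbonyl in place of 4-aminophenyl on an aromatic carbon). The entering group is the same one that compound 1 carries on its phenyl ring, but in compound 3 it sits directly on the shared core with no ring between.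

Because compound 1, which bears the (trifluoromethyl)carbonyl, gives 16 nM while compound 2 gives 90 nM, the expectation for compound 3 is a lower number than compound 2, a step from compound 2 to compound 3 estimated at a 3.0-fold lower number from compound 2 to compound 3 (0.48 log units; beyond the scatter), beyond the scatter but not large. The estimated value for compound 3 in this assay is 30 nM, with a range from 8 nM to 120 nM.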

Compound 3, inhibition constant: 4 nM
For compound 3 the middle estimate is 7.5-fold (0.88 log units) above the measured one; the measured number lies below the stated range.
By their numbers in this assay, from the lowest: compound 3; then compound 1; then compound 2.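

Putting (trifluoromethyl)carbonyl in place of 4-aminophenyl on the aromatic carbon next to the ring oxygen gives a 23-fold lower number from compound 2 to compound 3 (1.35 log units; beyond the scatter) in this assay, a large step. This shows that a six-membered aromatic ring on this position is not needed for a low number: compound 3 has no ring there, and its group has about the same heavy-atom count as the one it replaces, so the gain does not come with a larger group. The step swaps the ring, the nitrogen and the hydrogen-bond donor of 4-aminophenyl for the carbonyl and the three fluorine atoms all at once, and no measurement shown here gives a reason for its size.

The compounds shown leave open which part of the entering group carries the step, since a plain methyl ketone, a nitrile or a carboxylic acid on the same carbon would separate the carbonyl from the trifluoromethyl. They also leave open whether the step keeps its size with a shorter or longer chain in place of the phenyl-ended chain that all three compounds share.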